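Trimming the Side Chain: From Compound 2 to Compound 4

The compounds below may be only part of what the source reports. "The series", "measured", "known", "first", "only" and "open" are said of these compounds alone.

The measured compounds, all read in an assay for inhibition of Indoleamine 2,3-dioxygenase 1 (Homo sapiens), with stated times of 10 min and 60 min, tested at 100 uM; a lower number here means a weaker effect, a higher number a stronger effect of the compound at the concentration tested:
Compound 1, `NCCn1ncc2c(NCc3ccccc3[N+](=O)[O-])cc(C(F)(F)F)cc21`, gives 30%.
Compound 2, `O=C(O)CNc1cccc(CNc2cc(C(F)(F)F)cc3[nH]ncc23)c1`, gives 8%.
Compound 3, `O=[N+](O)c1c(Cl)cccc1CNc1cc(C(F)(F)F)cc2[nH]ncc12`, gives 69%.

Compound 2 stands lowest of the three numbers. Its nearest neighbour is compound 1, which lies higher by a margin beyond the scatter, and compound 3 lies further above it, again beyond the scatter. Among the measured compounds shown here, no two measured compounds differ in only one place, so no single step can be read from the measured set.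

Compound 4, `Nc1cccc(CNc2cc(C(F)(F)F)cc3[nH]ncc23)c1`, has not yet been measured in this assay. It differs from compound 2 in one place: hydrogen in place of carboxymethyl on a nitrogen on an aromatic ring. The change reads, cut one bond further out, as (carboxymethyl)amino to amino.

For the measured compounds named here, with no measured step of this kind to lean on, only the low starting point of compound 2 at 8% can guide the expectation. A small rise is expected, most likely within the scatter, as a number 7 percentage points higher from compound 2 to compound 4 (within the scatter). Compound 4 is therefore estimated at 15%, in a range from 0% to 40%.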

Compound 4, a percentage reported as inhibition, at one concentration (the size of the read-out at that concentration, not a potency): 55%
Estimate against measurement, compound 4: 40 percentage points below, outside the stated range (above it).
By their numbers in this assay, from the lowest: compound 2; then compound 1; then compound 4; then compound 3.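

In this assay, hydrogen in place of carboxymethyl on the nitrogen on an aromatic ring gives a number 47 percentage points higher from compound 2 to compound 4 (beyond the scatter). The earlier compounds shown here differed from one another in more than one place and could not show this; the step ties the low reading of compound 2 to the carboxymethyl on this nitrogen, not to the structure that compound 2 and compound 4 share. Nothing available accounts for the size of this step.

The compounds shown leave open whether a methyl group, an acetyl group or the methyl ester of the same chain on this nitrogen would read nearer compound 4 or nearer compound 2, and so whether the low number goes with the carboxylic acid or with the chain itself. They also leave open how a hydroxyl group in place of the amino group would read.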